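The compounds below may be only part of what the source reports. "The series", "measured", "known", "first", "only" and "open" are said of these compounds alone.

Measured compounds in a functional assay on K562 cells (Homo sapiens) for inhibition, read by thymidine incorporation, with a stated time of 48 h, tested at 10 ug/mL; on this read-out higher numbers stand for more inhibition at the one concentration tested (going by the name of the read-out) and lower numbers for less inhibition:
compound 1 `C(=C/c1[nH]cnc2ncnc1-2)\c1ccccc1` gives 28%
compound 2 `C(=C/c1[nH]cnc2ncnc1-2)\c1cccs1` gives 50%

Of these two, compound 2 gives the higher number, and its gap to compound 1 lies beyond the usual scatter of this read-out. Compound 3 `C/C(=C\C=C\c1[nH]cnc2ncnc1-2)CO` has not yet been measured. Compared with compound 2 it carries 2-(hydroxymethyl)prop-1-en-1-yl in place of thiophen-2-yl on a double-bonded chain carbon bound to a double-bonded chain carbon. Among the measured compounds shown here, no measured pair shows a change of this kind, so the size of the step is uncertain; the expectation is a drop that may reach beyond the scatter, an expected step of a number 20 percentage points lower from compound 2 to compound 3 (beyond the scatter) in this assay. Compound 3 is therefore estimated at 30%, with a range from 10% to 55%.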

Compound 3, a percentage reported as inhibition, at one concentration (the size of the read-out at that concentration, not a potency): 6%
Beside the measured number, compound 3's estimate is 24 percentage points above it; the measured number lies below the stated range.
By their numbers in this assay, from the lowest: compound 3; then compound 1; then compound 2.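

In this assay the position on a double-bonded chain carbon bound to a double-bonded chain carbon proves sensitive: putting 2-(hydroxymethyl)prop-1-en-1-yl in place of thiophen-2-yl gives a number 44 percentage points lower from compound 2 to compound 3 (beyond the scatter) as a large step. Both groups have the same heavy-atom count, yet the entering group has no ring and adds a hydrogen-bond donor. No available evidence accounts for this drop.
As far as these compounds go, the change removes the ring and adds the hydroxymethyl together, so their separate contributions remain open. A 2-methylprop-1-en-1-yl group or a furan-2-yl ring would each separate one change from the other.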